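The compounds below may be only part of what the source reports. "The series", "measured", "known", "first", "only" and "open" are said of these compounds alone.

In an ADME assay on microsomes from liver (Homo sapiens) for metabolic stability, with a stated time of 10 min (on this read-out higher numbers stand for a more stable compound and lower numbers for a less stable compound), two compounds have been measured so far. Compound 1 (`Cc1c(Cl)cccc1Oc1cccn2c(C3CCC(C)(O)CC3)nnc12`) gives 99%, and compound 2 (`COC12CCC(c3nnc4c(Oc5cccc(Cl)c5C)cccn34)(CC1)CC2`) gives 87%. Compound 2 is therefore the lower of the two, with a gap beyond the usual scatter of repeat measurements. Compound 3 (`Cc1c(Cl)cccc1Oc1cccn2c(C34CCC(O)(CC3)CC4)nnc12`) differs from compound 2 in one place: hydrogen in place of methyl on an oxygen on a saturated carbon. This puts hydrogen in place of methyl on an oxygen on a saturated carbon, turning methoxy into hydroxy. Among the compounds with values here, no measured pair shows this change directly, so the only guide is compound 1, which also carries a hydroxy group and gives 99%. A small rise is expected, not clearly beyond the scatter, and the estimated change is a number 7 percentage points higher from compound 2 to compound 3 (within the scatter). For compound 3 the expected value is 94%, with an estimated range from 84% to 100%.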

Compound 3, percent of the compound remaining: 100%
Estimate against measurement, compound 3: 6 percentage points below; the range from low to high includes it.
By their numbers in this assay, from the lowest: compound 2; then compounds 1 and 3 (each within the scatter of the next).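

In this assay, within the data shown here, this is the first direct reading of the change at this position: hydrogen in place of methyl on the oxygen, turning methoxy into hydroxy, gives a number 13 percentage points higher from compound 2 to compound 3 (beyond the scatter), so losing that single methyl separates the pair by more than repeat measurements would. The carbon group as a whole reads differently: the group of compound 3 in place of the smaller ring group of compound 1 gives a number 1 percentage points higher from compound 1 to compound 3 (within the scatter), so these two hydroxy-bearing groups cannot be told apart on this read-out. Nothing measured here explains why the methyl matters.

As far as these compounds go, it remains open whether an amine or a carboxylic acid in place of the hydroxy would read like compound 3 or like compound 2. A longer chain on the oxygen, such as ethoxy, is equally uncharted.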